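From ethyl to butyl on the chain

A few compounds are considered here, and "the series" means these few. Any claim that something is new, unique, unknown or untested is made for them only; others in the source may bear on it.

Measured in a functional assay (aorta) with Rattus norvegicus as the target (on this read-out lower numbers stand for an effect already at smaller amounts and higher numbers for an effect only at larger amounts of compound), so far
- Compound 1 `C/N=C(/S)C1=CC(C)(C)Oc2ccc([N+](=O)[O-])cc21` gives 1.35 nM
- Compound 2 `CCC1(C)C=C(/C(S)=N\C)c2cc([N+](=O)[O-])ccc2O1` gives 0.182 nM
- Compound 3 `CCCCC1(C)C=C(/C(S)=N\C)c2cc([N+](=O)[O-])ccc2O1` is not yet measured

Going by the values given here, compound 2 holds the lower of the two numbers so far. The change to compound 3 is ethyl in place of hydrogen on a saturated chain carbon, two bonds along the chain from a saturated ring carbon in all, ethyl in place of hydrogen on a saturated chain carbon, two bonds along the chain from a saturated ring carbon. Among the compounds with values here, the one step that bears on this, a 7.4-fold lower number from compound 1 to compound 2 (0.87 log units; beyond the scatter) and modest, put methyl in place of hydrogen on the chain. A single step cannot show whether the gain continues. In this assay no step beyond the scatter is therefore expected, with a 1.4-fold higher number from compound 2 to compound 3 (0.14 log units; within the scatter) as the estimated middle case. Compound 3 is expected at 0.25 nM with an estimated range from 0.04 nM to 1.5 nM for repeated measurements.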

Compound 3, half-maximal effective concentration: 40.7 nM
The estimate for compound 3 lay 160-fold (2.21 log units) below the measured number; the whole stated range lies below it.
By their numbers in this assay, from the lowest: compound 2; then compound 1; then compound 3.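

In this assay this position does not reward chain length steadily: the gain seen with the first added methyl reverses, with a 220-fold higher number from compound 2 to compound 3 (2.35 log units; beyond the scatter) for ethyl in place of hydrogen. The longer chain also overshoots the starting point, with a 30-fold higher number from compound 1 to compound 3 (1.48 log units; beyond the scatter) for propyl in place of hydrogen, so a small addition here and a larger one pull the number in opposite directions. Nothing measured here accounts for this reversal.

The compounds shown leave open how a propyl chain at this place would read, and so where along the chain the number turns upward. They also leave open whether a branched isopropyl group or a chain ending in an amine would behave like the butyl chain.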